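The compounds below may be only part of what the source reports. "The series", "measured", "known", "first", "only" and "open" are said of these compounds alone.

Measured in a functional assay on Bel-7402 cells (Homo sapiens) for inhibition, read by MTT assay, with a stated time of 24 h, tested at 10 ug/mL; a lower number here means less inhibition of growth, a higher number more inhibition of growth at the concentration tested:
- Compound 1 `O=C(CCCCC1CCSS1)Nc1cccc(C(F)(F)F)c1`: 4.43%
- Compound 2 `O=C(CCCCC1CCSS1)Nc1ccc([N+](=O)[O-])c(C(F)(F)F)c1`: "not active" (no number reported)
- Compound 3 `O=C(CCCCC(S)CCS)Nc1cccc(C(F)(F)F)c1`: 1.21%

Among the measured compounds shown here, the two numbers so far stand level: a number 3.2 percentage points lower from compound 1 to compound 3 (within the scatter). That step opens the ring and adds no nitro, so it bears only indirectly on what comes next.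

Compound 4 `O=C(CCCCC(S)CCS)Nc1ccc([N+](=O)[O-])c(C(F)(F)F)c1` carries nitro in place of hydrogen on an aromatic carbon of compound 3, ortho to a trifluoromethyl group and para to a large group: nitro in place of hydrogen on an aromatic carbon.

The same swap separates compound 1 from compound 2, and compound 2 is "not active" (no number reported), so that swap has no measured size. With compound 3 at 1.21%, no step beyond the scatter is expected in this assay. The expected step is a number 0.8 percentage points higher from compound 3 to compound 4 (within the scatter). The estimate for compound 4 is 2%, with an expected range from 0% to 8%.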

Compound 4, percent growth inhibition at one concentration: "not active" (no number reported)
The entry for compound 4 holds no number, and the estimate cannot be compared.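

Among the compounds shown here, compound 4, like compound 2, is reported as "not active" without a number, so no step from compound 3 to compound 4 can be read. As far as these compounds go, what swapping hydrogen for nitro does to the number stays open for both pairs. No measurement shown here bears on this result.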